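The source may report more compounds than this note shows. Statements on the series, on what has been measured and on what is new or still open speak of the compounds shown alone.

Measured compounds in a functional assay on the whole organism (strain albino) with Rattus norvegicus as the target, in the maximal electroshock model, with a stated time of 1 h, at a dose of 30 mg/kg by the intraperitoneal route; a higher number here means more inhibition at the dose given (going by the name of the read-out), a lower number less inhibition:
Compound 1 `Cc1nc2ccc(Br)cc2c(=O)n1NCc1nnc(N2C(=O)CSC2c2ccc(O)cc2)s1` gives 60%.
Compound 2 `Cc1nc2ccccc2c(=O)n1NCc1nnc(N2C(=O)CSC2c2ccc(O)cc2)s1` gives 60%.
Compound 3 `Cc1nc2ccc(Br)cc2c(=O)n1NCc1nnc(/N=C/c2ccc(O)cc2)s1` gives 50%.

Compound 2 stands level with compound 1 at the digits shown, and the value of compound 3 differs from that of compound 2 only by an amount within the scatter, so no ranking of the three can be drawn from these numbers. Among the compounds with values here, the one measured step between compounds that differ in a single place is no change at the digits printed from compound 1 to compound 2 (within the scatter), in which a bromo on the shared core was exchanged for hydrogen and the read-out stayed flat.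

The new compound is compound 4 `COc1cc(C2SCC(=O)N2c2nnc(CNn3c(C)nc4ccccc4c3=O)s2)ccc1O`. Its difference from compound 2 is methoxy in place of hydrogen on an aromatic carbon. Within the data shown here, no measured step touches this part of the molecule: the only recorded step concerns the bromo on the shared core, not the 4-hydroxyphenyl ring. That step showed no change, and all three measured numbers sit within the scatter of one another, so nothing in the data points to a shift in either direction for this new change. Compound 4 is therefore expected to give about 60%, estimated between 45% and 75%. The step of no change at the digits printed from compound 2 to compound 4 (within the scatter) that this estimate means is expected to be none beyond the scatter.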

Compound 4, a percentage reported as inhibition, in the whole organism at one dose (the size of the read-out at that dose, not a potency): 60%
The estimate for compound 4 equals the measured number at the digits printed; measured number inside the range.
By their numbers in this assay, from the lowest: compounds 3, 1, 2 and 4 (each within the scatter of the next).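

In this assay, placing methoxy on the aromatic carbon ortho to the hydroxy group, which turns 4-hydroxyphenyl into 4-hydroxy-3-methoxyphenyl, gives no change at the digits printed from compound 2 to compound 4 (within the scatter). Within the data shown here, this is the first measured step on this ring, as the earlier step concerned only the bromo on the shared core, and it shows that this position can carry a methoxy, a group of 2 heavy atoms, with no shift in the read-out beyond the scatter. Nothing at hand explains why the read-out holds steady here.

Methoxy is the only group shown at this position, so it remains open whether an amine, a carboxylic acid or a longer chain such as butoxy would leave the read-out equally flat or move it beyond the scatter. From the compounds shown here alone, the read-out is also taken at a single dose and is not a potency, so a difference between these compounds at other doses remains open too, as does the outcome of removing the hydroxy group itself.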